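A few compounds are considered here, and "the series" means these few. Any claim that something is new, unique, unknown or untested is made for them only; others in the source may bear on it.

Values measured in a functional assay on HCT-116 cells (Homo sapiens) for inhibition, read by CCK-8 assay, with a stated time of 72 h, tested at 2 uM; a lower number here means less inhibition of growth, a higher number more inhibition of growth at the concentration tested:
compound 1 `Cc1cc(C)cc(SCc2ccc(/C=C/C(=O)Nc3ccccc3N)cc2)c1`: 7.98%
compound 2 `COc1ccc(SCc2ccc(C(=O)Nc3ccccc3N)cc2)cc1`: 73.3%
compound 3 `CCc1ccc(SCc2ccc(C(=O)Nc3ccccc3N)cc2)cc1`: 40.7%

Compound 1 stands lowest of the three, clearly under both compound 3 and compound 2. Compound 4 `Cc1ccc(SCc2ccc(/C=C/C(=O)Nc3ccccc3N)cc2)cc1` keeps the core of compound 1 and changes one group: 4-methylphenyl in place of 3,5-dimethylphenyl on a sulfur. In words, 4-methylphenyl takes the place of 3,5-dimethylphenyl on a sulfur. For the measured compounds named here, no measured step covers this change. Going by the values given here, the only step available is a number 32.6 percentage points lower from compound 2 to compound 3 (beyond the scatter), with ethyl in place of methoxy on an aromatic carbon, and it belongs to a different core. Among the compounds with values here, it shows only that one group swap can move this number a long way. With compound 1 at 7.98%, little room remains below, so a rise is expected. The expected step is a number 14 percentage points higher from compound 1 to compound 4 (beyond the scatter), and it is quite uncertain. For compound 4 the estimated value is 22%, within a range of 5% to 50%.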

Compound 4, percent growth inhibition at one concentration: 6.23%
Compound 4: the middle estimate sits 15.8 percentage points above what was measured, within the range that was stated.
By their numbers in this assay, from the lowest: compounds 4 and 1 (each within the scatter of the next); then compound 3; then compound 2.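

In this assay, placing 4-methylphenyl instead of 3,5-dimethylphenyl on the sulfur gives a number 1.8 percentage points lower from compound 1 to compound 4 (within the scatter). On the core of compound 1, then, this swap does not measurably alter growth inhibition, so these two groups cannot be told apart at this position. No measurement available here bears on why the change makes so little difference.

Going by these compounds, it remains open whether a group of a different kind on the sulfur, such as an aromatic ring carrying an amine or a carboxylic acid, would move the number on this core.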